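This account rests on a few compounds, and the source may have more. Where it says the series, first, only, none or still open, it means among the compounds named here.

Of the compounds shown here, three share one core and have been measured in a functional assay on SW-620 cells (Homo sapiens) for cytotoxicity, read by MTT assay, with a stated time of 72 h; a lower number here means a stronger inhibitor, a higher number a weaker inhibitor. Compound 1 `COc1ccc(-c2cc(/N=C3/NC(=O)CS3)cs2)cc1` carries a methoxy group; in this assay compound 1 gives > 50000 nM, which is a limit of the assay and not a number. Compound 2 `O=C1CS/C(=N\c2csc(-c3ccc(Cl)cc3)c2)N1` carries a chloro group instead; in this assay compound 2 gives > 50000 nM, again a limit rather than a number. For the measured compounds named here, the only step between measured compounds, a step that the two limits leave unreadable from compound 1 to compound 2, therefore cannot be sized. Going by the values given here, compound 3 `Cc1ccc(/C=C2\S/C(=N\c3csc(-c4ccc(Cl)cc4)c3)NC2=O)cc1` adds a 4-methylphenyl methylidene arm to the core of compound 2, and in this assay compound 3 gives 1500 nM, the only actual number among the three values.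

Compound 4 `CN(C)c1ccc(/C=C2\S/C(=N\c3csc(-c4ccc(Cl)cc4)c3)NC2=O)cc1` differs from compound 3 in one place: dimethylamino in place of methyl on an aromatic carbon. Among the compounds with values here, no measured step speaks to this change, since the single sized comparison between measured compounds is unreadable and concerns another part of the molecule. With nothing pointing in either direction, the expectation is that compound 4 stays near compound 3, a step of a 1.4-fold lower number from compound 3 to compound 4 (0.13 log units; within the scatter) that is not expected to exceed the usual scatter. Compound 4 is therefore estimated at 1100 nM, with a range from 300 nM to 5000 nM.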

Compound 4, half-maximal inhibitory concentration: 800 nM
The estimate for compound 4 lay 1.4-fold (0.14 log units) above the measured number; low and high end bracket the measured number.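

In this assay, dimethylamino in place of methyl on an aromatic carbon, para to a large group, gives a 1.9-fold lower number from compound 3 to compound 4 (0.27 log units; within the scatter), so this change leaves the two compounds indistinguishable in this measurement. For the compounds shown here, this is the first step that can be read as a size, and it shows that a group of 3 heavy atoms with a hydrogen-bond acceptor can stand where a single carbon stood, with no step beyond the usual scatter. Compound 1 and compound 2 could not show this, as each gives a limit of the assay and not a number: the limit of > 50000 nM in this assay, at which 2 of the 4 values shown sit.

Going by these compounds, two groups are a small sample of this position, so it remains open whether a carboxylic acid, an amine carrying a hydrogen, or a longer alkyl chain placed there would give a number in the same range. On these data alone, it is also open whether the same arm keeps a readable number when the chloro group at the other end of the molecule gives way to methoxy.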